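From benzyl to 3-fluorophenyl on the amine nitrogen

The source may report more compounds than this note shows. Statements on the series, on what has been measured and on what is new or still open speak of the compounds shown alone.

In a functional assay on ECa-109 cells for inhibition, with ECa-109 cell line (Homo sapiens) as the target, read by sulforhodamine B assay (on this read-out higher numbers stand for weaker inhibition and lower numbers for stronger inhibition), compound 1 `O=C1C(Nc2ccc(I)cc2)=CC(=O)c2c1nc1n2[C@H]2OC[C@@H](O)[C@H]2OC1` gives 2530 nM. Compound 2 `CCOc1ccc(NC2=CC(=O)c3c(nc4n3[C@H]3OC[C@@H](O)[C@H]3OC4)C2=O)cc1` gives > 4000 nM, which is a limit. Compound 3 `O=C1C(NCc2ccccc2)=CC(=O)c2c1nc1n2[C@H]2OC[C@@H](O)[C@H]2OC1` gives > 8000 nM, also a limit and not a number, so its standing is known only as a limit. Compound 4 `O=C1C(Nc2cccc(F)c2)=CC(=O)c2c1nc1n2[C@H]2OC[C@@H](O)[C@H]2OC1` has 3-fluorophenyl in place of benzyl on an amine nitrogen. The closest guide is the opposite kind of swap, benzyl in place of 4-iodophenyl, with an at least 3.1-fold higher number from compound 1 to compound 3 (0.49 log units; beyond the scatter). Less can be drawn from an at least 1.5-fold higher number from compound 1 to compound 2 (0.19 log units; that floor lies within the scatter), and a step that the two limits leave unreadable from compound 2 to compound 3 gives no size. A modest move to a lower number is therefore expected. The estimated change is an at least 2.6-fold lower number from compound 3 to compound 4 (0.42 log units; beyond the scatter). For compound 4 the expected value is 3000 nM, within an estimated range of 1400 nM to 7000 nM.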

Compound 4, half-maximal inhibitory concentration: 2370 nM
The estimate for compound 4 lay 1.3-fold (0.10 log units) above the measured number; the range from low to high includes it.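

In this assay, 3-fluorophenyl on the amine nitrogen gives an at least 3.3-fold lower number from compound 3 to compound 4 (0.52 log units; beyond the scatter), a floor set by the limit of compound 3: the limit of > 8000 nM in this assay, at which 1 of the 4 values shown sits. Against 4-ethoxyphenyl the change gives an at least 1.6-fold lower number from compound 2 to compound 4 (0.22 log units; that floor lies within the scatter), a floor set by the limit of compound 2: the limit of > 4000 nM in this assay, at which 1 of the 4 values shown sits. Against 4-iodophenyl it gives a 1.1-fold lower number from compound 1 to compound 4 (0.03 log units; within the scatter), so these two halogen-bearing phenyl groups cannot be told apart on this read-out.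

Still open, going by these compounds, is whether 4-fluorophenyl or unsubstituted phenyl on the same nitrogen would read alike. On these data alone, the true sizes of the two steps resting on limits also remain unknown.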